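This account rests on a few compounds, and the source may have more. Where it says the series, first, only, none or still open, it means among the compounds named here.

Values in a functional assay on SNU-423 cells (Homo sapiens) for inhibition, read by MTT assay, with a stated time of 72 h; on this read-out lower numbers stand for stronger inhibition and higher numbers for weaker inhibition:
- compound 1 `Nc1ncnc2c1c(-c1cnc3[nH]ccc3c1)nn2CCCCCCCCC(=O)NO`: 7500 nM
- compound 2 `Nc1nc2cc(-c3nn(CCCCCCCCCC(=O)NO)c4ncnc(N)c34)ccc2o1`: > 50000 nM
- compound 3 `Nc1ncnc2c1c(-c1cnc3[nH]ccc3c1)nn2CCCCCCCCCC(=O)NO`: 8160 nM

Compound 2 has no number, only a limit of the assay, > 50000 nM.

Compound 4 `Nc1nc2cc(-c3nn(CCCCCC(=O)NO)c4ncnc(N)c34)ccc2o1` differs from it by hydroxycarbamoyl in place of 4-(hydroxycarbamoyl)butyl on a saturated chain carbon, five bonds along the chain from an aromatic nitrogen. In words, hydroxycarbamoyl stands in place of 4-(hydroxycarbamoyl)butyl on a saturated chain carbon, five bonds along the chain from an aromatic nitrogen.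

Among the measured compounds shown here, the only measured chain change is a 1.1-fold higher number from compound 1 to compound 3 (0.04 log units; within the scatter), which is within the scatter, and it is a smaller change made with a different group on the core. The other step, an at least 6.1-fold lower number from compound 2 to compound 3 (0.78 log units; beyond the scatter), exchanges that group and leaves the chain alone, and compound 4 keeps the group of compound 2. A chain change of this size is unmeasured, so only a modest move towards a lower number is expected, and another limit remains possible. The expected step is an at least 1.6-fold lower number from compound 2 to compound 4 (0.22 log units; that floor lies within the scatter). For compound 4 the estimate in this assay is 30000 nM, with an expected range of 6000 nM to 100000 nM.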

Compound 4, half-maximal inhibitory concentration: 12600 nM
Compound 4: middle estimate off by 2.4-fold (0.38 log units), on the high side; the range from low to high includes it.
By their numbers in this assay, from the lowest: compounds 1, 3 and 4 (each within the scatter of the next). At a limit, above all of these: compound 2.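

In this assay, replacing 4-(hydroxycarbamoyl)butyl with hydroxycarbamoyl at this position gives an at least 3.9-fold lower number from compound 2 to compound 4 (0.59 log units; beyond the scatter), so the chain length here can matter with the group of compound 2. The other chain step, a 1.1-fold higher number from compound 1 to compound 3 (0.04 log units; within the scatter), carries a different group and showed no such change. Compound 2 has only a limit of the assay, so the new step is a floor: the limit of > 50000 nM in this assay, at which 1 of the 4 values shown sits.

From the compounds shown here alone, whether a similar shortening matters with the group of compound 1 stays open. Also open, going by these compounds, is what a carboxylic acid or an amine would give in place of hydroxycarbamoyl on the chain of compound 4.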